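The source may report more compounds than this note shows. Statements on the series, on what has been measured and on what is new or still open speak of the compounds shown alone.

Compound 3 `CCCC(Oc1ccc(-n2cccn2)cc1)c1ccc(C(=O)NCCC(=O)O)cc1`, compound 1 `CCCC(Oc1ccc(-n2cc(C(=O)N(C)C)cn2)cc1)c1ccc(C(=O)NCCC(=O)O)cc1` and compound 2 `CCCC(Oc1ccc(-n2cc(C#N)cn2)cc1)c1ccc(C(=O)NCCC(=O)O)cc1` share one core and were all tested in a functional assay on cells for antagonist activity at Glucagon receptor (Homo sapiens), read by cAMP accumulation, in the presence of a further agent that is not named here; on this read-out lower numbers stand for stronger inhibition and higher numbers for weaker inhibition. Compound 3 reached only the assay limit, giving > 55000 nM. Compound 1 also gave only a limit, > 30000 nM. Compound 2 likewise gave a limit, > 50000 nM. All three values are limits, so the steps a step that the two limits leave unreadable from compound 1 to compound 2, a step that the two limits leave unreadable from compound 1 to compound 3 and a step that the two limits leave unreadable from compound 2 to compound 3 have no readable size; changing the group on this aromatic carbon of the shared core has so far shown no measurable effect. Compound 4 `CCCC(Oc1ccc(-n2cc(F)cn2)cc1)c1ccc(C(=O)NCCC(=O)O)cc1` differs from compound 3 by fluoro in place of hydrogen on an aromatic carbon. For the measured compounds named here, no measured step gives a size for this change, so compound 4 is expected to stay at a limit, with an estimated step that the limit leaves unreadable from compound 3 to compound 4. The estimated value for compound 4 in this assay is 60000 nM, in a range from 20000 nM to 200000 nM.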

Compound 4, antagonist equilibrium constant: 10000 nM
Estimate against measurement, compound 4: 6.0-fold (0.78 log units) above; measured number outside the range, below it.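

For the compounds shown here, compound 4 is the first compound here to give a measured number instead of a limit, so this aromatic carbon of the five-membered ring can affect the read-out. Fluoro in place of hydrogen gives an at least 5.5-fold lower number from compound 3 to compound 4 (0.74 log units; beyond the scatter), fluoro in place of cyano gives an at least 5.0-fold lower number from compound 2 to compound 4 (0.69 log units; beyond the scatter), and fluoro in place of dimethylcarbamoyl gives an at least 3.0-fold lower number from compound 1 to compound 4 (0.47 log units; beyond the scatter). Each size is only a minimum, because the other compound in each pair stands at a limit, for example: the limit of > 55000 nM in this assay, at which 1 of the 4 values shown sits.

From the compounds shown here alone, whether this effect is specific to fluoro remains open. Chloro, methyl or an amine on the same carbon would test that.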